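The source may report more compounds than this note shows. Statements on the series, on what has been measured and on what is new or still open speak of the compounds shown alone.

Measured in a functional assay on MDA-MB-231 cells (Homo sapiens) for antiproliferative activity, read by MTT assay, with a stated time of 24 h; on this read-out lower numbers stand for stronger inhibition and higher numbers for weaker inhibition:
- compound 1 `O=C(NNc1ccccc1F)c1cccc(NS(=O)(=O)c2cnc(O)nc2O)c1`: > 20000 nM
- compound 2 `O=C(NNc1ccc(F)cc1)c1cccc(NS(=O)(=O)c2cnc(O)nc2O)c1`: > 20000 nM
- compound 3 `Cc1ccc(C(=O)NNC(=O)c2cccc(NS(=O)(=O)c3cnc(O)nc3O)c2)cc1`: > 20000 nM

Each of these three values is a limit of the assay and not a number. Compound 3 stands with the other two at the limit of > 20000 nM in this assay, at which 3 of the 3 values shown sit.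

Compound 4 `O=C(NNC(=O)c1ccccc1Cl)c1cccc(NS(=O)(=O)c2cnc(O)nc2O)c1` differs from compound 3 in one place, with 2-chlorophenyl in place of 4-methylphenyl on a carbonyl carbon.

Among the measured compounds shown here, three measured steps bear on this change: a step that the two limits leave unreadable from compound 1 to compound 3, a step that the two limits leave unreadable from compound 2 to compound 3 and a step that the two limits leave unreadable from compound 1 to compound 2. None of them has a size that can be read. For the measured compounds named here, no compound has yet given a number in this assay, so these steps point to no direction, and no step beyond the scatter is expected. Compound 4 is most likely to be reported only as a limit as well.

The expected step is a step that the limit leaves unreadable from compound 3 to compound 4. For compound 4 the estimated value is 25000 nM. The expected range for that estimate runs from 12000 nM to 60000 nM.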

Compound 4, half-maximal inhibitory concentration: 2360 nM
For compound 4 the middle estimate is 11-fold (1.03 log units) above the measured one; measured number below the stated range.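

In this assay, among the compounds shown here, the group on the carbonyl carbon is the first place where a change gives a readable step: 2-chlorophenyl in place of 4-methylphenyl gives an at least 8.4-fold lower number from compound 3 to compound 4 (0.92 log units; beyond the scatter), a minimum size, as the starting value is a limit of the assay and not a number. The (2-chlorophenyl)carbonyl group on the amine nitrogen also gives an at least 8.4-fold lower number from compound 2 to compound 4 (0.92 log units; beyond the scatter) in place of 4-fluorophenyl and an at least 8.4-fold lower number from compound 1 to compound 4 (0.92 log units; beyond the scatter) in place of 2-fluorophenyl. The steps among the other three compounds cannot be read, and compound 4 alone leaves the limit: the limit of > 20000 nM in this assay, at which 3 of the 4 values shown sit.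

Going by these compounds, the true size of these steps remains open, as does whether the chlorine or its ring position carries the change. A 4-chlorophenyl or 2-methylphenyl group on the same carbonyl carbon would separate those two readings.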